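This account rests on a few compounds, and the source may have more. Where it says the series, first, only, none or still open, it means among the compounds named here.

Compound 1 `CC1(C)CCOc2ccc(NC(=O)Nc3ccc([N+](=O)[O-])cc3)cc21`, which in a functional assay on A2780 cells (Homo sapiens) for inhibition, with a stated time of 72 h, tested at 10 uM (on this read-out higher numbers stand for more inhibition of growth at the one concentration tested and lower numbers for less inhibition of growth), gives 74%, and compound 2 `CC1(C)CCOc2ccc(NC(=O)Nc3ccc(OC(F)(F)F)cc3)cc21`, which in this assay gives 36%.

Among the measured compounds shown here, compound 2 stands lowest of these two numbers; the single measured step, a number 38 percentage points lower from compound 1 to compound 2 (beyond the scatter), replaced one group on an aromatic carbon with another. Compound 3 `CC1(C)CCOc2ccc(NC(=O)Nc3ccc(C(F)(F)F)cc3)cc21` keeps the shared core and differs from compound 2 by trifluoromethyl in place of trifluoromethoxy on an aromatic carbon. For the measured compounds named here, no measured step swaps these two groups, so the only hint is that altering this group at all moved this assay strongly. The change from trifluoromethoxy to trifluoromethyl is expected to stay within the scatter, a number 4 percentage points higher from compound 2 to compound 3 (within the scatter). Compound 3 is therefore estimated at 40%, between 20% and 65%.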

Compound 3, percent growth inhibition at one concentration: 47%
Beside the measured number, compound 3's estimate is 7 percentage points below it; low and high end bracket the measured number.
By their numbers in this assay, from the lowest: compound 2; then compound 3; then compound 1.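

In this assay, the change to trifluoromethyl gives a number 11 percentage points higher from compound 2 to compound 3 (beyond the scatter), so even these two closely related fluorinated groups are told apart at this position. Nitro still stays ahead, with a number 27 percentage points lower from compound 1 to compound 3 (beyond the scatter), and it holds the top place among the three groups. No available evidence explains this order.

Still open, on these data alone, is whether the lead of nitro belongs to nitro alone or would be shared by a nitrile or a carboxylic acid at this position. How an amine would fare there is also unknown.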